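A few compounds are considered here, and "the series" means these few. Any claim that something is new, unique, unknown or untested is made for them only; others in the source may bear on it.

Three compounds share one core and differ only in the group sitting on an oxygen on an aromatic ring. In an assay on cells for binding affinity to Neuropeptide Y receptor type 1 (Homo sapiens) (a lower number here means a stronger inhibitor, a higher number a weaker inhibitor), compound 1 `CCc1sc(CCc2cc(OC(CC)CC)cc(NCc3cc(Cl)cc(NC(=O)OC(C)C)c3)n2)nc1C` gives 5.5 nM. Compound 2 `CCc1sc(CCc2cc(OC3CCCCC3)cc(NCc3cc(Cl)cc(NC(=O)OC(C)C)c3)n2)nc1C` gives 29 nM in this assay. Compound 3 `CCc1sc(CCc2cc(OC3CCOCC3)cc(NCc3cc(Cl)cc(NC(=O)OC(C)C)c3)n2)nc1C` gives 4.4 nM in this assay and stands at the low end of the three: the step of a 1.3-fold lower number from compound 1 to compound 3 (0.10 log units; within the scatter), whereas a 6.6-fold lower number from compound 2 to compound 3 (0.82 log units; beyond the scatter).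

Compound 4 `CCc1sc(CCc2cc(OCCCc3cccnc3)cc(NCc3cc(Cl)cc(NC(=O)OC(C)C)c3)n2)nc1C` brings the change (3-(pyridin-3-yl)propyl in place of oxan-4-yl on an oxygen on an aromatic ring). Among the measured compounds shown here, the steps that bear on it are those at the same oxygen: a 5.3-fold higher number from compound 1 to compound 2 (0.72 log units; beyond the scatter), a 1.3-fold lower number from compound 1 to compound 3 (0.10 log units; within the scatter) and a 6.6-fold lower number from compound 2 to compound 3 (0.82 log units; beyond the scatter). As far as these compounds go, none of them puts a chain carrying an aromatic ring there, so the direction stays open and a modest shift either way is what these steps allow. Compound 4 is therefore expected to give 10 nM in this assay, between 3 nM and 35 nM, an expected step of a 2.3-fold higher number from compound 3 to compound 4 (0.36 log units; beyond the scatter).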

Compound 4, half-maximal inhibitory concentration: 6.5 nM
Compound 4: middle estimate off by 1.5-fold (0.19 log units), on the high side; low and high end bracket the measured number.
By their numbers in this assay, from the lowest: compounds 3, 1 and 4 (each within the scatter of the next); then compound 2.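

In this assay, among the compounds shown here, the oxygen on an aromatic ring accepts a 3-(pyridin-3-yl)propyl chain, the first group here with an aromatic ring, without a change beyond the scatter: a 1.5-fold higher number from compound 3 to compound 4 (0.17 log units; within the scatter) and a 1.2-fold higher number from compound 1 to compound 4 (0.07 log units; within the scatter). Compound 2 alone stands apart, with a 4.5-fold lower number from compound 2 to compound 4 (0.65 log units; beyond the scatter), so among these four compounds the cyclohexyl group is the one exception. No evidence is available to explain these results. As far as these compounds go, what a 3-phenylpropyl group or a longer chain ending in pyridin-3-yl would give at this oxygen remains open.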